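Series notes: the step from compound 3 to compound 4

The source may report more compounds than this note shows. Statements on the series, on what has been measured and on what is new or still open speak of the compounds shown alone.

In a functional assay on ileum for antagonist activity at muscarinic acetylcholine receptor M3 (Cavia porcellus) (on this read-out higher numbers stand for weaker inhibition and lower numbers for stronger inhibition), compound 3 `O=C(CN1CCN(C/C=C\c2ccccc2)CC1)C(O)(c1ccccc1)C1CCC1` gives 9.92 nM, the lowest of the two numbers in hand on this read-out. Compound 2 `C#CCN1CCN(CC(=O)C(O)(c2ccccc2)C2CCCCC2)CC1` gives 260 nM in this assay, a higher number than compound 3, the two differing also in the cycloalkyl group on the shared core. Compound 1 `CCOC(=O)N1CCN(CC(=O)C(O)(c2ccccc2)C2CCCCC2)CC1` returns only a limit, > 10000 nM, in this assay. Going by the values given here, the single measured step, an at least 38-fold lower number from compound 1 to compound 2 (1.58 log units; beyond the scatter), is the only guide to substituent changes on the ring nitrogen: the ethoxycarbonyl compound sits at the limit (the limit of > 10000 nM in this assay, at which 1 of the 3 values shown sits), while the propargyl compound gives a number. Compound 4 `O=C(CN1CCN(CC(=O)C(O)(c2ccccc2)C2CCC2)CC1)N1CCCC1` differs from compound 3 as follows: (pyrrolidin-1-yl)carbonyl in place of 2-phenylethenyl on a saturated chain carbon bound to an amine nitrogen in a ring. Here the ring nitrogen stays bonded to a saturated chain carbon and the (pyrrolidin-1-yl)carbonyl sits one bond further out, so the measured step bears only loosely; still, the six-membered aromatic ring leaves and a carbonyl-bearing group enters. A clearly higher number in this assay is expected for compound 4, by a step of a 20-fold higher number from compound 3 to compound 4 (1.30 log units; beyond the scatter). The estimate for compound 4 is accordingly 200 nM, with a range from 40 nM to 1500 nM.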

Compound 4, antagonist equilibrium constant: 210 nM
The estimate for compound 4 lay 1.1-fold (0.02 log units) below the measured number; measured number inside the range.
By their numbers in this assay, from the lowest: compound 3; then compounds 4 and 2 (each within the scatter of the next). At a limit, above all of these: compound 1.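

Going by these compounds alone, on the ring nitrogen of the shared core, going from 3-phenylprop-2-en-1-yl to ((pyrrolidin-1-yl)carbonyl)methyl in this assay gives a large change (a 21-fold higher number from compound 3 to compound 4 (1.33 log units; beyond the scatter)), the first measured step at this position in which the saturated chain carbon bound to the amine nitrogen stays in place and only the group on it is exchanged. The change removes the 2-phenylethenyl group, with its six-membered aromatic ring of carbon only, and brings in a five-membered non-aromatic ring and a hydrogen-bond acceptor, yet compound 4 still returns a number on this read-out and not a limit, so this position tolerates the exchange with a loss and not with a complete fall to the limit of the assay. No measurement shown gives a cause for the size of this step.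

Still open, on these data alone, is whether the higher number follows the loss of the six-membered aromatic ring or the entry of the (pyrrolidin-1-yl)carbonyl, since the two changes travel together in this pair. A 2-oxo-2-phenylethyl group, holding an aromatic ring and a carbonyl together, or a saturated 3-phenylpropyl chain would pull these apart.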